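The source may hold more compounds than are shown below. What is called first, only, known or untested is meant among the compounds shown, and "the series" means these compounds.

Compound 3 `CC(=O)c1cc(/C=C/c2ccc(F)cc2)cc2cc(-c3ccccc3)[nH]c12` was tested in a functional assay on MCF7 cells (Homo sapiens) for cytotoxicity, read by MTT assay, with a stated time of 2 days, tested at 100 uM (a higher number here means a weaker effect of the compound at the concentration tested, a lower number a stronger effect), where compound 3 gives 46.7%. Among the three compounds measured so far that is the second highest number. The nearest neighbour is compound 1 `CC(=O)c1cc(-c2ccccc2)cc2cc(-c3ccc(F)cc3)[nH]c12`, which gives 73.3%; the furthest is compound 2 `COc1ccc(-c2cc(C(C)=O)c3[nH]c(-c4ccc(F)cc4)cc3c2)cc1`, which gives 14.8%. Compound 4 `CC(=O)c1cc(/C=C/c2ccc(F)cc2)cc2cc(-c3ccc(F)cc3)[nH]c12` has not been measured yet. Compared with compound 3 it carries one change: fluoro in place of hydrogen on an aromatic carbon, para to a large group, so that a phenyl becomes a 4-fluorophenyl.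

Only one measured step exists among these compounds, a number 58.5 percentage points lower from compound 1 to compound 2 (beyond the scatter), and it concerns a methoxy entering on another part of the molecule, so it speaks to the fluoro change only loosely. For the measured compounds named here, compound 1, which already carries a 4-fluorophenyl, and compound 3, which carries a phenyl at that position, differ in more than one place, so their two values show only that both give higher numbers than compound 2. With so little to go on, a step in this assay of modest size, in either direction, is the fair expectation for compound 4.

For compound 4 the expected value in this assay is 40%, with a range from 15% to 68%. The step this estimate implies, a number 6.7 percentage points lower from compound 3 to compound 4 (within the scatter), is expected to stay within the usual scatter.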

Compound 4, a percentage reported as activity, at one concentration (the size of the read-out at that concentration, not a potency): 42.2%
The estimate for compound 4 lay 2.2 percentage points below the measured number, within the range that was stated.
By their numbers in this assay, from the lowest: compound 2; then compounds 4 and 3 (each within the scatter of the next); then compound 1.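

In this assay, fluoro in place of hydrogen on an aromatic carbon, para to a large group, gives a number 4.5 percentage points lower from compound 3 to compound 4 (within the scatter). For the compounds shown here, this is the first direct reading of the phenyl to 4-fluorophenyl change, and with 2-(4-fluorophenyl)ethenyl on the other side of the shared core it does not separate the two compounds. With the 4-fluorophenyl held fixed, the other substituent makes a clear difference, and in both directions: 2-(4-fluorophenyl)ethenyl in place of phenyl gives a number 31.1 percentage points lower from compound 1 to compound 4 (beyond the scatter), while 2-(4-fluorophenyl)ethenyl in place of 4-methoxyphenyl gives a number 27.4 percentage points higher from compound 2 to compound 4 (beyond the scatter), and no measurement at hand explains any of these steps.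

Going by these compounds, this rests on a single pair, so it remains open whether the phenyl to 4-fluorophenyl change would also stay within the scatter alongside the 4-methoxyphenyl group or the plain phenyl. Also open, on these data alone, is whether something larger or very different from fluoro on that ring, such as an amine or a carboxylic acid, would shift the number in this assay beyond the scatter.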